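The source may hold more compounds than are shown below. What is called first, only, known or untested is meant among the compounds shown, and "the series" means these compounds.

This study compares four small molecules in a functional assay on HEL cells (Homo sapiens) for cytotoxicity; on this read-out lower numbers stand for higher toxicity in this test and higher numbers for lower toxicity in this test. Two of them share a core built on a saturated six-membered ring: compound 3 `CC(C)C1NC(=O)N(C2CCCCC2)C1=O` and compound 1 `CCC(C)C1NC(=O)N(C2CCCCC2)C1=O`. The other two share a different core: compound 2 `CC(C)C(NC(=O)n1nnc2ccccc21)C(=O)NC1CCCC1` and compound 4 `CCC(C)C(NC(=O)n1nnc2ccccc21)C(=O)NC1CCCC1`, the last of which has not yet been measured. The difference between the two cores is not broken down here.

In this assay compound 3 reaches only the limit of the test, > 50 ug/mL, which is a limit and not a number. Compound 1 likewise reaches only a limit, > 50 ug/mL. For the measured compounds named here, compound 2 is the one compound with a measured number: in this assay compound 2 gives 200 ug/mL.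

Compound 3 turns into compound 1 by methyl in place of hydrogen on a saturated chain carbon, two bonds along the chain from a saturated ring carbon, and the step in this assay is a step that the two limits leave unreadable from compound 3 to compound 1, since both values sit at the limit of > 50 ug/mL in this assay, at which 2 of the 3 values shown sit. Compound 2 turns into compound 4 by methyl in place of hydrogen on a saturated chain carbon, three bonds along the chain from an amide-type nitrogen and a carbonyl carbon. This is the same kind of change, though the surroundings differ: in the first pair the place is two bonds along the chain from a saturated ring carbon, in the second it is three bonds along the chain from an amide-type nitrogen and a carbonyl carbon.

Beside the unreadable earlier step, the step from compound 2 to compound 4 is expected to be small, a 1.1-fold lower number from compound 2 to compound 4 (0.05 log units; within the scatter), because the shown step that the two limits leave unreadable from compound 3 to compound 1 gives no sign of a large effect. Compound 4 is therefore estimated at 180 ug/mL, with a likely range from 90 ug/mL to 360 ug/mL.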

Compound 4, half-maximal cytotoxic concentration: 87.3 ug/mL
For compound 4 the middle estimate is 2.1-fold (0.31 log units) above the measured one; the measured number lies below the stated range.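

In this assay, putting a methyl in place of hydrogen on the core of compound 2 gives a 2.3-fold lower number from compound 2 to compound 4 (0.36 log units; beyond the scatter), so here the change from isopropyl to sec-butyl goes with higher toxicity in this test. The same change on the core of compound 1 cannot be read, as compound 3 and compound 1 each give only a limit and not a number: the limit of > 50 ug/mL in this assay, at which 2 of the 4 values shown sit. The result therefore rests on one readable pair and shows a modest step on one core only; it does not show that the change carries over from one core to the other, neither in direction nor in size, and the surroundings of the change also differ between the pairs.

Still open, going by these compounds, is whether the step on the core of compound 2 continues with a longer chain, such as pentyl, or changes when an amine or a carboxylic acid enters in place of the methyl. Also open, on these data alone, is how the same change behaves on the core of compound 1, where a comparison would need a pair with readable numbers.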